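The source may report more compounds than this note shows. Statements on the series, on what has been measured and on what is new or still open speak of the compounds shown alone.

Measured so far:
compound 1 `O=C(COc1ccc2cc(C(O)(C(F)(F)F)C(F)(F)F)c(O)cc2c1)Nc1ccc(-c2ccccc2)cc1` — 2800 nM
compound 2 `Oc1ccc(-c2ccccc2)cc1C(O)(C(F)(F)F)C(F)(F)F` — > 500000 nM

For the measured compounds named here, in an assay on isolated protein for inhibition of tyrosine-protein phosphatase non-receptor type 13 (Homo sapiens), read by spectrophotometry (on this read-out higher numbers stand for weaker inhibition and lower numbers for stronger inhibition), compound 1 gives 2800 nM, and this is the only actual number in hand, so compound 1 is the reference point. For compound 2 the assay reports only a limit of > 500000 nM, not a number. Going by the values given here, compound 2 is a much smaller molecule without the chain that carries the amide of compound 1, and the limit of > 500000 nM in this assay, at which 1 of the 2 values shown sits, shows only that no inhibition was detected for it; with no measured step between the two, the values say nothing more.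

Compound 3 `Cc1ccc(S(=O)(=O)NNC(=O)COc2ccc3cc(C(O)(C(F)(F)F)C(F)(F)F)c(O)cc3c2)cc1` has not been measured yet. It differs from compound 1 by ((4-methylphenyl)sulfonyl)amino in place of 4-phenylphenyl on an amide-type nitrogen. Among the compounds with values here, no measured step covers a change of this kind, so the size of the step from compound 1 to compound 3 is open. The expectation is a loss of potency somewhat beyond the usual scatter, since the group that enters is more polar and smaller than the one that leaves, though that is a guess without support in the data. Compound 3 is expected to give 8000 nM, with a range from 2000 nM to 40000 nM. That estimate means a step of a 2.9-fold higher number from compound 1 to compound 3 (0.46 log units; beyond the scatter) towards weaker inhibition.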

Compound 3, half-maximal inhibitory concentration: 14900 nM
For compound 3 the middle estimate is 1.9-fold (0.27 log units) below the measured one; low and high end bracket the measured number.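

In this assay, for the compounds shown here, putting ((4-methylphenyl)sulfonyl)amino in place of 4-phenylphenyl on the amide-type nitrogen gives the first measured step at this position: a 5.3-fold higher number from compound 1 to compound 3 (0.73 log units; beyond the scatter), towards weaker inhibition. The group on this nitrogen therefore affects the read-out, yet compound 3 still gives 14900 nM, a real number rather than a limit, even with one aromatic ring here where compound 1 has two. Nothing measured here gives a reason for this step.

The step combines two differences, the loss of one aromatic ring and the arrival of the sulfonyl group with its nitrogen, and the compounds shown do not separate them. From the compounds shown here alone, it also stays open whether a plain phenyl, a benzyl or a carboxylic acid on this nitrogen would give a value nearer to compound 1 or to compound 3.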